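The source may report more compounds than this note shows. Statements on the series, on what has been measured and on what is new or still open speak of the compounds shown alone.

The series consists of diphenylmethyl sulfoxides that carry a small heteroaromatic group on the methylene attached to sulfur. In an assay on HEK293 cells for inhibition of sodium-dependent dopamine transporter (Homo sapiens), read by scintillation counting, with stated times of 5 min and 1 min (a higher number here means a weaker inhibitor, a lower number a stronger inhibitor), compound 1 `CC(C)c1nnsc1C[S+]([O-])C(c1ccccc1)c1ccccc1` gives 69100 nM. Compound 2 `Cc1scc(C[S+]([O-])C(c2ccccc2)c2ccccc2)c1C`, in this assay, gives 284000 nM, and the step of a 4.1-fold higher number from compound 1 to compound 2 (0.61 log units; beyond the scatter) shows that exchanging one heteroaromatic group for another at this position moves the number noticeably, though all of these compounds sit at very weak inhibition. Compound 3 `Cc1nnc(C[S+]([O-])C(c2ccccc2)c2ccccc2)s1` is recorded in this assay as "not active" (no number reported), with no number attached, so its standing relative to compound 1 and compound 2 cannot be placed on a scale; it can only be said that nothing measurable was seen.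

Compound 4 `[O-][S+](Cc1ccncc1)C(c1ccccc1)c1ccccc1` differs from compound 3 by pyridin-4-yl in place of 5-methyl-1,3,4-thiadiazol-2-yl on a saturated chain carbon bound to a sulfur. For the measured compounds named here, no measured step bears directly on this exchange. Going by the values given here, the only step available, from compound 1 to compound 2, shows that swapping one small heteroaromatic group for another at this position changes the number by a modest amount, and compound 3 itself gave no measurable inhibition. Compound 4 is therefore expected to remain a very weak inhibitor in this assay, and it is estimated at 200000 nM, with a range from 40000 nM to 1000000 nM, with a real chance that again only inactivity is reported.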

Compound 4, half-maximal inhibitory concentration: 63500 nM
Compound 4: the middle estimate sits 3.1-fold (0.50 log units) above what was measured; low and high end bracket the measured number.
By their numbers in this assay, from the lowest: compounds 4 and 1 (each within the scatter of the next); then compound 2.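

In this assay compound 4 gives a number although compound 3 was recorded as not active, so the change from (5-methyl-1,3,4-thiadiazol-2-yl)methyl to (pyridin-4-yl)methyl goes with measurable inhibition, but with no number for compound 3, the steps involving it cannot be read. Pyridin-4-yl in place of 4,5-dimethylthiophen-3-yl gives a 4.5-fold lower number from compound 2 to compound 4 (0.65 log units; beyond the scatter), whereas pyridin-4-yl in place of 4-isopropyl-1,2,3-thiadiazol-5-yl gives a 1.1-fold lower number from compound 1 to compound 4 (0.04 log units; within the scatter), which shows that a six-membered aromatic ring can serve at this position as well as the substituted thiadiazole of compound 1 and that the dimethylthiophene of compound 2 is the one set apart. No measurement is available that explains these differences.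

The compounds shown leave open whether a plain phenyl ring, a pyridin-2-yl or pyridin-3-yl group, or a pyridin-4-yl ring carrying a methyl or an amine would move the number away from the very weak range seen so far. They also leave open whether a longer chain between the sulfur and the ring, or a sulfide or sulfone in place of the sulfoxide, would change the picture.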